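This account rests on a few compounds, and the source may have more. Where it says the series, first, only, none or still open, it means among the compounds named here.

Measured compounds:
`CCCCC(C)C/C(=C/[C@@]1(CC)OC(=O)C[C@@H]1O)CC` compound 1, a functional assay on K562 cells (Homo sapiens) for cytotoxicity, read by MTT assay, with a stated time of 72 h; a lower number here means a stronger inhibitor, a higher number a weaker inhibitor: 49200 nM
`CCCC[C@H](CC)C[C@]1(CC)C=C(CC)/C(=C/C(=O)OC)O1` compound 2, this assay: 5300 nM

Compound 1 gives the highest number of the two and is the weaker inhibitor, with compound 2 well beyond the scatter below it. Compound 3, `CCCCC(C)C/C(=C\[C@@]1(CC)OC(=O)C[C@@H]1O)CC`, differs from compound 1 only in one way: the two compounds have the same atoms and bonds; at least one stereo element is drawn with a configuration in one of them and without one in the other: 1 of 4 stereo elements differ; a double bond is drawn E in compound 1 and Z in compound 3. Among the measured compounds shown here, no pair of measured compounds shows what such a change does here, so a step in either direction is possible; a modest one, expected to stay close to the scatter, is taken as the likeliest, a 1.2-fold lower number from compound 1 to compound 3 (0.09 log units; within the scatter). Compound 3 is therefore expected at 40000 nM, within 10000 nM to 150000 nM.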

Compound 3, half-maximal inhibitory concentration: 2200 nM
Compound 3: the middle estimate sits 18-fold (1.26 log units) above what was measured, and the stated range ends above it.
By their numbers in this assay, from the lowest: compound 3; then compound 2; then compound 1.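

The geometry of the double bond alone, with atoms and bonds unchanged, carries a large effect in this assay: a 22-fold lower number from compound 1 to compound 3 (1.35 log units; beyond the scatter). Until now nothing showed how this double bond bears on the number, and the Z-drawn compound 3 now lies well beyond the scatter from compound 1. The step is read with one reservation: the fact that one of compounds 1 and 3 is drawn with a defined configuration and the other without, at the place where they differ.

Still open, as far as these compounds go, is whether the same change in geometry has a like effect on a longer chain, and whether an amine in place of the hydroxyl would keep the number of compound 3.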